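A few compounds are considered here, and "the series" means these few. Any claim that something is new, unique, unknown or untested is made for them only; others in the source may bear on it.

Compound 1 `N#Cc1ccccc1C1OCC(C/C=C\CCC(=O)O)C(c2cccnc2)O1`: in an assay for inhibition of Thromboxane-A synthase (Homo sapiens), using microsomes (a higher number here means a weaker inhibitor, a lower number a stronger inhibitor), compound 1 gives 54 nM.
Compound 2 `O=C(O)CC/C=C\CC1COC(c2ccc(C(F)(F)F)cc2)OC1c1cccnc1`: in this assay compound 2 gives 44 nM.
Compound 3 `O=C(O)CC/C=C\CC1COC(c2ccsc2)OC1c1cccnc1`: in this assay compound 3 gives 500 nM.

Compound 2 holds the lowest of the three numbers. Its nearest neighbour is compound 1, and the step of a 1.2-fold lower number from compound 1 to compound 2 (0.09 log units; within the scatter) lies within the scatter, so the two cannot be told apart. Compound 3 lies furthest off, with an 11-fold higher number from compound 2 to compound 3 (1.06 log units; beyond the scatter).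

Compound 4 `O=C(O)CC/C=C\CC1COC(c2ccc3ccccc3c2)OC1c1cccnc1` differs from compound 2 in one place: naphthalen-2-yl in place of 4-(trifluoromethyl)phenyl on a saturated ring carbon. Within the data shown here, two measured steps bear on this position. Swapping one aryl group for another, from compound 1 to compound 2, gave a 1.2-fold lower number from compound 1 to compound 2 (0.09 log units; within the scatter), whereas the move to thiophen-3-yl gave an 11-fold higher number from compound 2 to compound 3 (1.06 log units; beyond the scatter) and a 9.3-fold higher number from compound 1 to compound 3 (0.97 log units; beyond the scatter). Naphthalen-2-yl keeps a six-membered aromatic ring of carbon only at this position, as in compound 1 and compound 2, so the account expects only a small step in this assay, possibly none beyond the scatter; the expected step is a 1.4-fold higher number from compound 2 to compound 4 (0.13 log units; within the scatter). Compound 4 is therefore estimated at 60 nM, with a range from 20 nM to 200 nM.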

Compound 4, half-maximal inhibitory concentration: 50 nM
Beside the measured number, compound 4's estimate is 1.2-fold (0.08 log units) above it; measured number inside the range.
By their numbers in this assay, from the lowest: compounds 2, 4 and 1 (each within the scatter of the next); then compound 3.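

On the saturated ring carbon between two ring oxygen atoms, a group with 2 six-membered aromatic rings of carbon only fits this assay as well as a group with one: naphthalen-2-yl gives a 1.1-fold higher number from compound 2 to compound 4 (0.06 log units; within the scatter) and a 1.1-fold lower number from compound 1 to compound 4 (0.03 log units; within the scatter), so the larger aromatic group and the loss of the three fluorine atoms produce no readable step. Thiophen-3-yl remains the only group here that stands apart, with a 10-fold lower number from compound 3 to compound 4 (1.00 log units; beyond the scatter). Nothing measured here explains why these aryl groups match or why thiophen-3-yl differs.

The compounds shown leave open whether an amine on the aromatic group, or a plain alkyl chain in its place, would keep the number of compound 4. They also leave open whether a furan-3-yl group would stand with thiophen-3-yl or with the carbon-only aromatic groups.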